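Chain extension on the core methyl of compound 1

The source may hold more compounds than are shown below. What is called first, only, known or untested is meant among the compounds shown, and "the series" means these compounds.

Going by the values given here, compound 1 `Cn1c(Cc2nn(C)c(=O)c3ccccc23)nnc1SCCCCCCCC(=O)Nc1ccc(Cl)cc1Cl` is the only member of this set that gives a number: in an assay on 32D cells for inhibition of interleukin-15 (Mus musculus), read by resazurin assay, with stated times of 30 min and 2.5 days, in the presence of a further agent that is not named here (on this read-out higher numbers stand for weaker inhibition and lower numbers for stronger inhibition), compound 1 gives 3900 nM. Compound 2 `Cn1nc(Cc2nnc(SCCCCCCCC(=O)Nc3ccc(Cl)cc3Cl)n2CCCO[Si](C)(C)C(C)(C)C)c2ccccc2c1=O` gives in this assay only the limit > 30000 nM, not a number. Compound 3 `Cn1nc(Cc2nnc(SCCCCCCCC(=O)Nc3ccc(Cl)cc3Cl)n2CCCO)c2ccccc2c1=O` likewise returns in this assay only the limit > 30000 nM. Both steps away from compound 1 ran the same way: an at least 7.6-fold higher number from compound 1 to compound 2 (0.88 log units; beyond the scatter) and an at least 7.6-fold higher number from compound 1 to compound 3 (0.88 log units; beyond the scatter), each reaching (the limit of > 30000 nM in this assay, at which 2 of the 3 values shown sit). Between compound 2 and compound 3 the step is unreadable, a step that the two limits leave unreadable from compound 2 to compound 3.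

Compound 4 `Cn1c(Cc2nn(CCC=O)c(=O)c3ccccc23)nnc1SCCCCCCCC(=O)Nc1ccc(Cl)cc1Cl` carries the change (formylmethyl in place of hydrogen on a saturated chain carbon bound to an aromatic nitrogen), read one bond further out as methyl to 2-formylethyl, so it sits at the same place as the two measured extensions. Both of those moved to the limit, and the same direction is expected here: a weaker number, a 6.4-fold higher number from compound 1 to compound 4 (0.81 log units; beyond the scatter), with a real chance that only a limit is returned. Compound 4 is therefore expected at 25000 nM, within 8000 nM to 70000 nM.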

Compound 4, half-maximal inhibitory concentration: 11700 nM
For compound 4 the middle estimate is 2.1-fold (0.33 log units) above the measured one, and the stated range covers the measured number.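

In this assay the formyl-bearing chain weakens the read-out without taking it to the limit, with a 3.0-fold higher number from compound 1 to compound 4 (0.48 log units; beyond the scatter). Going by these compounds alone, compound 4 therefore shows that a saturated chain carbon bound to an aromatic nitrogen can carry formylmethyl in place of hydrogen and still return a number, and its chain stands on the other such carbon of the shared core, not the one extended in compounds 2 and 3. Those two compounds remain limits, not numbers, so a chain on their carbon has not yet given a readable step: the limit of > 30000 nM in this assay, at which 2 of the 4 values shown sit.

Going by these compounds, whether a carboxylic acid or a primary amine at the end of the 2-formylethyl chain, or a longer chain, keeps a number remains open. Also open, on these data alone, is how the same 2-formylethyl chain would read on the carbon extended in compounds 2 and 3.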